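The compounds below may be only part of what the source reports. "The series", "measured", "known", "first", "only" and "open" are said of these compounds alone.

Measured so far in an assay on isolated protein for inhibition of Rho-associated protein kinase 1 (Homo sapiens), read by scintillation counting, radiometric assay and 33P incorporation, with a stated time of 40 min, in the presence of a further agent that is not named here; a higher number here means a weaker inhibitor, a lower number a stronger inhibitor:
compound 1 `O=C(COc1ccc2c(=O)ccoc2c1)Nc1cccc(NC(=O)c2ccccc2)c1` gives 120 nM
compound 2 `O=C(COc1ccc2c(=O)ccoc2c1)Nc1cccc(NS(=O)(=O)c2ccc(C(F)(F)F)cc2)c1` gives > 10000 nM
compound 3 `CN(C)c1ccc(C(=O)Nc2ccc(NC(=O)COc3ccc4c(=O)ccoc4c3)cc2)cc1` gives 1050 nM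

Compound 3 holds the highest of the two numbers given; compound 1 sits lower, by a gap beyond the usual scatter. For compound 2 the result in this assay is only a limit, not a number, as the limit of > 10000 nM in this assay, at which 1 of the 3 values shown sits, records. Compound 4 `Cc1cc(NC(=O)COc2ccc3c(=O)ccoc3c2)ccc1NC(=O)c1ccc(N(C)C)cc1` is compound 3 with methyl in place of hydrogen on an aromatic carbon. Among the compounds with values here, no measured pair shows this change on its own, so there is nothing to scale it by; the expected step, a 1.1-fold lower number from compound 3 to compound 4 (0.02 log units; within the scatter), is none beyond the scatter. Compound 4 is therefore estimated at 1000 nM, within 300 nM to 3500 nM.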

Compound 4, half-maximal inhibitory concentration: > 10000 nM
Compound 4 was reported as a limit (the forecaster's own chance of this, stated with the estimate: 10%); middle value at least 10-fold (1.00 log units) away from the limit.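

Adding one methyl to an aromatic carbon, ortho to a large group and meta to a large group, gives in this assay an at least 9.5-fold higher number from compound 3 to compound 4 (0.97 log units; beyond the scatter). Even the addition of a single carbon at this position can therefore matter greatly in this series. The result for compound 4, > 10000 nM, is a limit and not a number, and other compounds in this small set reach the same limit: the limit of > 10000 nM in this assay, at which 2 of the 4 values shown sit.

On these data alone, how a fluorine atom or a methoxy group on this same carbon would read remains open. So does whether a methyl on another carbon of this ring would cost as much.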